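The source may report more compounds than this note shows. Statements on the series, on what has been measured and on what is new or still open speak of the compounds shown alone.

Values measured so far in a functional assay on A549 cells (Homo sapiens) for inhibition, read by MTT assay, with a stated time of 72 h; a higher number here means a weaker inhibitor, a lower number a stronger inhibitor

- compound 1 `COc1cc2c(Oc3ccc(NC(=O)c4nn(-c5ccc(Cl)c(C(F)(F)F)c5)cc(C)c4=O)cc3)ccnc2cc1OCC(=O)NO` gives 1590 nM
- compound 2 `COc1cc2c(Oc3ccc(NC(=O)c4nn(-c5ccccc5C)cc(C)c4=O)cc3F)ccnc2cc1OCCCC(=O)NO` gives 2090 nM
- compound 3 `COc1cc2c(Oc3ccc(NC(=O)c4nn(-c5ccccc5)cc(C)c4=O)cc3F)ccnc2cc1OCCCC(=O)NO` gives 1900 nM

Compound 2 does not separate from the other two, since its value lies within the scatter of both compound 1 and compound 3. The next compound is compound 4 `COc1cc2c(Oc3ccc(NC(=O)c4nn(-c5ccccc5C)ccc4=O)cc3F)ccnc2cc1OCCCC(=O)NO`, which differs from compound 2 by one exchange (hydrogen in place of methyl on an aromatic carbon), hydrogen in place of methyl on an aromatic carbon, opposite the ring nitrogen. Within the data shown here, no measured compound lacks this methyl, so the effect of removing it has not been observed directly. Among the measured compounds shown here, the only step of the same kind lies elsewhere, on the 2-methylphenyl group, and compound 3 shows it as a 1.1-fold lower number from compound 2 to compound 3 (0.04 log units; within the scatter). That step is a guide to size only and gives no direction. In this assay no step beyond the scatter is therefore expected, and the estimate is a 1.0-fold lower number from compound 2 to compound 4 (0.02 log units; within the scatter) as the expected change. For compound 4 the estimated value is 2000 nM, with an expected range from 900 nM to 4500 nM in this estimate.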

Compound 4, half-maximal inhibitory concentration: 5740 nM
Compound 4: middle estimate off by 2.9-fold (0.46 log units), on the low side; the whole stated range lies below it.
By their numbers in this assay, from the lowest: compounds 1, 3 and 2 (each within the scatter of the next); then compound 4.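

In this assay, the methyl opposite the ring nitrogen is not interchangeable with hydrogen: the exchange gives a 2.7-fold higher number from compound 2 to compound 4 (0.44 log units; beyond the scatter), a modest step. The same kind of exchange on the 2-methylphenyl group gives a 1.1-fold lower number from compound 2 to compound 3 (0.04 log units; within the scatter), so a step read at one place in this series does not carry over to the other. Nothing on hand accounts for the step at the carbon opposite the ring nitrogen.

Open, as far as these compounds go, is whether an ethyl group, a chlorine atom or a methoxy group on this carbon would keep the number near that of compound 2 or bring it near that of compound 4. Also open, from the compounds shown here alone, is whether removing this methyl gives a step of similar size when the plain phenyl group of compound 3 replaces the 2-methylphenyl group.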